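The source may report more compounds than this note shows. Statements on the series, on what has been measured and on what is new or still open speak of the compounds shown alone.

In a functional assay on ileum (Cavia porcellus) for antagonist activity (on this read-out lower numbers stand for stronger inhibition and higher numbers for weaker inhibition), compound 1 `Cc1ccc(CCCCOc2ccc3c(O)c([N+](=O)[O-])c(=O)oc3c2)cc1` gives 2500 nM. Compound 2 `N#Cc1ccc(OCCCOc2ccc3c(O)c([N+](=O)[O-])c(=O)oc3c2)cc1` gives only a limit, > 10000 nM. Compound 3 `O=c1oc2cc(OCCCOc3ccc(-c4ccccc4)cc3)ccc2c(O)c1[N+](=O)[O-]` also gives only a limit, > 20000 nM. Compound 4 `Cc1ccc(OCCCOc2ccc3c(O)c([N+](=O)[O-])c(=O)oc3c2)c([N+](=O)[O-])c1`, not yet measured, carries 4-methyl-2-nitrophenyl in place of 4-cyanophenyl on an oxygen on a saturated carbon. Within the data shown here, two measured steps bear on this change, though neither introduces that group. The step of an at least 4.0-fold higher number from compound 1 to compound 2 (0.60 log units; beyond the scatter) is beyond the scatter and leads to weaker inhibition, while the step that the two limits leave unreadable from compound 2 to compound 3 gives no readable size. Neither supports expecting a clear recovery of inhibition, so the expected change is small, with no firm direction: a step that the limit leaves unreadable from compound 2 to compound 4. The estimate for compound 4 is 12000 nM, with an expected range of 3000 nM to 40000 nM.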

Compound 4, half-maximal inhibitory concentration: > 10000 nM
Compound 4 gave a limit, no number; the forecaster's own chance of this, stated with the estimate: 55%; the middle value lies beyond the limit too.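

In this assay compound 4 gives only a limit, > 10000 nM. Compound 2 also gives only a limit, > 10000 nM, so no step can be read between these two compounds. Going by these compounds, whether 4-methyl-2-nitrophenyl and 4-cyanophenyl differ in inhibition stays open.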